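The source may report more compounds than this note shows. Statements on the series, on what has been measured and on what is new or still open speak of the compounds shown alone.

Measured compounds in an assay on cells for displacement of a labelled ligand from corticotropin-releasing factor receptor 1 (Homo sapiens), with a stated time of 100 min; a lower number here means a stronger inhibitor, a higher number a weaker inhibitor:
- compound 1 `Cc1cc(C)c(-n2c(Cl)cn3c(CN(C)Cc4ccco4)c(C(F)(F)F)nc23)c(C)c1`: 180 nM
- compound 2 `Cc1cc(C)c(-n2c(Cl)cn3c(CN4CCC(c5ccccc5)C4)c(C(F)(F)F)nc23)c(C)c1`: 610 nM

For the measured compounds named here, compound 2 gives the highest of the two numbers in this assay; the only step to it, a 3.4-fold higher number from compound 1 to compound 2 (0.53 log units; beyond the scatter), exchanged the amine attached to the shared core and was modest but beyond the scatter.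

Compound 3 `Cc1cc(C)c(-n2c(Cl)cn3c(CN4CCC(C)CC4)c(C(F)(F)F)nc23)c(C)c1` is not yet measured in this assay. It differs from compound 2 as follows: 4-methylpiperidin-1-yl in place of 3-phenylpyrrolidin-1-yl on a saturated chain carbon bound to an aromatic carbon. The change sits at the same point as the step from compound 1 to compound 2, so that step is the only one bearing on it; it shows that exchanging this amine moves the number by a modest amount. Compound 3 again carries a smaller amine than compound 2, so a modest step back toward the number of compound 1 is expected, a 1.9-fold lower number from compound 2 to compound 3 (0.28 log units; within the scatter), with little certainty about size.

Compound 3 is estimated at 320 nM, expected to fall between 100 nM and 1000 nM.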

Compound 3, inhibition constant: 3200 nM
Compound 3: the middle estimate sits 10-fold (1.00 log units) below what was measured; the measured number lies above the stated range.
By their numbers in this assay, from the lowest: compound 1; then compound 2; then compound 3.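

For the compounds shown here, at the saturated chain carbon bound to an aromatic carbon, the amine can shift the number in this assay much further than the first exchange indicated: the change to 4-methylpiperidin-1-yl gives a 5.2-fold higher number from compound 2 to compound 3 (0.72 log units; beyond the scatter) and, against the furan-containing amine, an 18-fold higher number from compound 1 to compound 3 (1.25 log units; beyond the scatter) as the only large step in the set. The entering group has fewer heavy atoms than 3-phenylpyrrolidin-1-yl, yet the number rises, so a smaller amine at this place does not by itself lead back toward compound 1. Nothing available explains this order.

Going by these compounds, it remains open whether the ring or its methyl group accounts for the high number of compound 3; piperidin-1-yl and morpholin-4-yl at this place would separate the two. Also open, on these data alone, is whether the furan ring of compound 1 matters, which benzyl(methyl)amino in its place would test.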